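Swapping the sulfur substituent in a shared core

The source may report more compounds than this note shows. Statements on the series, on what has been measured and on what is new or still open speak of the compounds shown alone.

Measured compounds in a functional assay on MCF7 cells (Homo sapiens) for antiproliferative activity, read by MTT assay, with a stated time of 48 h; on this read-out lower numbers stand for stronger inhibition and higher numbers for weaker inhibition:
- compound 1, `Cc1ccc(-c2nc(NC(=O)c3ccccc3)c3cc(Cl)ccc3n2)cc1`: 16.1 ug/mL
- compound 2, `C=CCSc1nc(-c2ccc(C)cc2)nc2ccc(Cl)cc12`: 8.03 ug/mL
- compound 3, `Cc1ccc(-c2nc(Sc3ncccc3[N+](=O)[O-])c3cc(Cl)ccc3n2)cc1`: 3.56 ug/mL

Compound 3 gives the lowest number of the three in this assay. Its nearest neighbour is compound 2, and the step of a 2.3-fold lower number from compound 2 to compound 3 (0.35 log units; beyond the scatter) lies beyond the scatter, while compound 1 sits furthest away. The earlier step of a 2.0-fold lower number from compound 1 to compound 2 (0.30 log units; within the scatter) is within the scatter.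

Compound 4, `Cc1ccc(-c2nc(SCCO)c3cc(Cl)ccc3n2)cc1`, has not yet been measured. It differs from compound 3 in one place: 2-hydroxyethyl in place of 3-nitropyridin-2-yl on a sulfur. The step that bears on this change is a 2.3-fold lower number from compound 2 to compound 3 (0.35 log units; beyond the scatter), in which a small allyl chain on the same sulfur was replaced by the 3-nitropyridin-2-yl group and the number fell modestly. Among the measured compounds shown here, compound 4 moves back to a small chain on that sulfur, so a modest rise in the number, roughly undoing that step, is expected, though the 2-hydroxyethyl group is not the allyl group of compound 2 and no measured compound carries it. For compound 4 the expected step is a 2.5-fold higher number from compound 3 to compound 4 (0.40 log units; beyond the scatter), giving an estimate of 9 ug/mL with a range of 4 ug/mL to 25 ug/mL.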

Compound 4, half-maximal inhibitory concentration: 3.76 ug/mL
Estimate against measurement, compound 4: 2.4-fold (0.38 log units) above; the whole stated range lies above it.
By their numbers in this assay, from the lowest: compounds 3 and 4 (each within the scatter of the next); then compounds 2 and 1 (each within the scatter of the next).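

In this assay, the ring of the 3-nitropyridin-2-yl group proves unnecessary on this sulfur: moving to the ringless 2-hydroxyethyl chain, with 3 heavy atoms in place of 9, gives a 1.1-fold higher number from compound 3 to compound 4 (0.02 log units; within the scatter) and so stays within the scatter. A small chain on the sulfur therefore does not settle the number by itself, since the two small chains differ at their ends and there is a 2.1-fold lower number from compound 2 to compound 4 (0.33 log units; beyond the scatter) with hydroxymethyl in place of vinyl, while the change of the whole group on the aromatic carbon, (2-hydroxyethyl)sulfanyl in place of benzamido, gives a 4.3-fold lower number from compound 1 to compound 4 (0.63 log units; beyond the scatter) and is also modest. Nothing available here explains why these steps have the sizes they do.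

Still open, as far as these compounds go, is whether the hydroxyl itself matters, which a methoxyethyl, an aminoethyl or a longer 3-hydroxypropyl chain on the same sulfur would help show. Also open, from the compounds shown here alone, is whether a plain pyridin-2-yl ring without the nitro group would behave like 3-nitropyridin-2-yl.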